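Furan to hydroxybutenolide swap on the labdane-type series

The source may report more compounds than this note shows. Statements on the series, on what has been measured and on what is new or still open speak of the compounds shown alone.

Compound 2 `C=C(C)CCC[C@]1(C)C2=CCC[C@](C)(C[C@H](O)c3ccoc3)[C@H]2CC[C@H]1C` gives 59400 nM in a functional assay on HeLa cells (Homo sapiens) for antiproliferative activity, read by XTT assay, with a stated time of 72 h (a higher number here means a weaker inhibitor, a lower number a stronger inhibitor), the highest of the three numbers recorded. Compound 1 `C=C(C)CC[C@]1(C)C2=CCC[C@](C)(C[C@@H](O)c3ccoc3)[C@H]2CC[C@H]1C` gives 30200 nM in this assay, within the scatter of compound 2. Compound 3 `C=C(C)CC[C@]1(C)C2=CCC[C@](C)(C[C@@H](OC(C)=O)C3=CC(=O)OC3O)[C@H]2CC[C@H]1C`, which carries the ring-opened oxidised five-membered ring with an acetate, gives 6700 nM, a gap to compound 2 that lies beyond the scatter.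

Compound 4 `C=C(C)CCC[C@]1(C)C2=CCC[C@](C)(C[C@@H](O)C3=CC(=O)OC3O)[C@H]2CC[C@H]1C` keeps the skeleton of compound 2 and changes only the side group: a group of 9 heavy atoms (5 carbon, 4 oxygen; one five-membered non-aromatic ring with 1 hetero atom) in place of a group of 7 heavy atoms (5 carbon, 2 oxygen; one five-membered aromatic ring with 1 hetero atom), on a saturated chain carbon bound to a saturated ring carbon

Within the data shown here, no measured pair isolates this change. Because compound 3 gives 6700 nM with a related oxidised ring, the expected step from compound 2 to compound 4 is downward and beyond the scatter, a 5.0-fold lower number from compound 2 to compound 4 (0.69 log units; beyond the scatter). Compound 4 is estimated at 12000 nM in this assay, with a range from 4000 nM to 40000 nM.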

Compound 4, half-maximal inhibitory concentration: 2600 nM
For compound 4 the middle estimate is 4.6-fold (0.66 log units) above the measured one; the measured number lies below the stated range.
By their numbers in this assay, from the lowest: compound 4; then compound 3; then compounds 1 and 2 (each within the scatter of the next).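

On the saturated chain carbon bound to a saturated ring carbon, exchanging (furan-3-yl)(hydroxy)methyl for the non-aromatic five-membered ring group gives, in this assay, a 23-fold lower number from compound 2 to compound 4 (1.36 log units; beyond the scatter), a large step. Among these compounds, it is the only single-place comparison, and the earlier compounds offered no pair that isolated this change. No measured evidence bears on the origin of this step.

From the compounds shown here alone, whether the ring hydroxy group is needed remains open, as a methoxy group there would test. Going by these compounds, how an amine or a carboxylic acid at this chain position would compare also remains open.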